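A Fluorine-for-Chlorine Swap on a Thiazole Amide

The compounds below may be only part of what the source reports. "The series", "measured", "known", "first", "only" and "open" are said of these compounds alone.

Measured so far:
- compound 1, `O=C(Nc1cc(-c2nc3ccccc3s2)ccc1Cl)c1cc([N+](=O)[O-])ccc1Cl`: "below limit of detection" (no number reported)
- compound 2, `O=C(Nc1nc(-c2ccc(Cl)cc2)cs1)c1cc([N+](=O)[O-])ccc1Cl`: 3 10^-6 cm/s
- compound 3, `O=C(Nc1ccc(O)c(-c2nc3ccccc3s2)c1)c1cc([N+](=O)[O-])ccc1Cl`: "below limit of detection" (no number reported)

In an ADME assay for permeability, using PAMPA, at pH 7.4 (a higher number here means that the compound crosses the layer faster, a lower number that the compound crosses the layer more slowly), compound 1 gives no single number, "below limit of detection" (no number reported). Compound 3 likewise gives no single number in this assay, "below limit of detection" (no number reported). Among the measured compounds shown here, compound 2 is the sole compound with a number in this assay, giving 3 10^-6 cm/s, so no measured step exists to guide the next one. Compound 4, `O=C(Nc1nc(-c2cccc(F)c2)cs1)c1cc([N+](=O)[O-])ccc1Cl`, differs from compound 2 by 3-fluorophenyl in place of 4-chlorophenyl on an aromatic carbon. For the measured compounds named here, no step between measured compounds is known, so the expectation rests on the change alone; a step within the scatter is expected. Compound 4 is expected to give 2.5 10^-6 cm/s, between 1 10^-6 cm/s and 6 10^-6 cm/s, an expected step of a 1.2-fold lower number from compound 2 to compound 4 (0.08 log units; within the scatter).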

Compound 4, apparent permeability: 3 10^-6 cm/s
For compound 4 the middle estimate is 1.2-fold (0.08 log units) below the measured one; measured number inside the range.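

Among the compounds shown here, the swap of 4-chlorophenyl for 3-fluorophenyl, on the aromatic carbon next to the ring nitrogen, provides the first readable step at this place in this assay: no change at the digits printed from compound 2 to compound 4 (within the scatter). This position therefore tolerates this exchange of one aryl group for another without a step beyond the scatter. Nothing available explains this result. Going by these compounds, because the halogen and its ring position change together, their separate contributions stay open. Also open, on these data alone, is whether an amine or a carboxylic acid on this phenyl ring would move the read-out.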